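This account rests on a few compounds, and the source may have more. Where it says the series, first, only, none or still open, it means among the compounds named here.

Measured in a functional assay on MGC-803 cells (Homo sapiens) for inhibition; on this read-out lower numbers stand for stronger inhibition and higher numbers for weaker inhibition:
Compound 1 `O=C(CC(CC(=O)NC1Cc2ccccc2C1)c1ccc(Cl)cc1)NCCN1CCCCC1`: 89100 nM
Compound 2 `CCN(CC)CCNC(=O)CC(CC(=O)NC1Cc2ccccc2C1)c1ccc(Cl)cc1`: > 100000 nM (a limit of the assay)
Compound 3 `O=C(CC(CC(=O)NC1Cc2ccccc2C1)c1ccccc1)NCCN1CCCCC1`: > 100000 nM (a limit of the assay)

Compound 1 alone carries a number, 89100 nM. The rest of the series offers only (the limit of > 100000 nM in this assay, at which 2 of the 3 values shown sit).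

Compound 4 `CCN(C(=O)CC(CC(=O)NCCN1CCCCC1)c1ccc(Cl)cc1)C1Cc2ccccc2C1` comes from compound 1 by a single change, ethyl in place of hydrogen on an amide-type nitrogen.

Neither measured step touches that nitrogen, so both bear on the change only indirectly. One is an at least 1.1-fold higher number from compound 1 to compound 2 (0.05 log units; that floor lies within the scatter), with diethylamino in place of piperidin-1-yl. The other is an at least 1.1-fold higher number from compound 1 to compound 3 (0.05 log units; that floor lies within the scatter), with hydrogen in place of chloro on an aromatic carbon. On these data alone, each gives only a floor that lies within the scatter, and the true size of either step remains unknown.

As far as these compounds go, no step beyond the scatter is therefore expected in this assay, and the direction stays open. The estimated change is a 1.1-fold higher number from compound 1 to compound 4 (0.05 log units; within the scatter). Compound 4 may well return only a limit. For compound 4 the estimated value is 100000 nM, with an expected range from 35000 nM to 200000 nM.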

Compound 4, half-maximal inhibitory concentration: 21200 nM
The estimate for compound 4 lay 4.7-fold (0.67 log units) above the measured number; the whole stated range lies above it.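

In this assay, the amide-type nitrogen whose other neighbours are a carbonyl carbon and a saturated ring carbon proves to be a position where a single change has a measurable effect: ethyl in place of hydrogen gives a 4.2-fold lower number from compound 1 to compound 4 (0.62 log units; beyond the scatter). The amide hydrogen at this position is therefore not required for the inhibition seen with compound 1, and a substituent there is tolerated and goes with the stronger value. The earlier steps to compound 2 and compound 3 cannot be read for size, because both compounds sit at a limit: the limit of > 100000 nM in this assay, at which 2 of the 4 values shown sit.

On these data alone, what methyl or a longer chain such as propyl would do on the same nitrogen stays open. So does whether the ethyl step would carry over to the diethylamino or the unchlorinated analogue, and the compounds shown give no reason for the step.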